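The source may report more compounds than this note shows. Statements on the series, on what has been measured and on what is new or still open speak of the compounds shown alone.

Series notes. The shared core of compound 1 `CCCSc1nc(Cl)c2c(n1)N(Cc1ccccc1)C(C(=O)OCC)N2` carries an ethoxycarbonyl group; in a functional assay on PC-3 cells (Homo sapiens) for antiproliferative activity, read by MTT assay, with a stated time of 72 h (on this read-out lower numbers stand for stronger inhibition and higher numbers for weaker inhibition), compound 1 gives 62500 nM. Compound 2 `CCCSc1nc(Cl)c2c(n1)N(Cc1ccco1)C(C(=O)N1CCN(C)CC1)N2` differs from compound 1 at several places. In this assay compound 2 gives 11400 nM. Compound 1 thus stands at the highest of the two numbers in hand, and compound 2, the nearest, sits well lower, beyond the scatter. Going by the values given here, no pair differing in one place has been measured, so no single-site step can be read from the measured compounds.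

Compound 3 `CCCSc1nc(Cl)c2c(n1)N(Cc1ccccc1)C(C(=O)O)N2` is the one-place partner of compound 1: hydrogen in place of ethyl on an oxygen next to a carbonyl group. Among the compounds with values here, the only guide is the pair of numbers above, and neither tells what this change does on its own. The working expectation is that compound 3 stays in the weak range of compound 1, with a step no larger than the scatter or a modest move to a higher number, a 1.4-fold higher number from compound 1 to compound 3 (0.13 log units; within the scatter). Compound 3 is therefore estimated at 85000 nM, within 30000 nM to 250000 nM. At numbers this high the measurement may well return only a limit.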

Compound 3, half-maximal inhibitory concentration: 49200 nM
Beside the measured number, compound 3's estimate is 1.7-fold (0.24 log units) above it; the range from low to high includes it.
By their numbers in this assay, from the lowest: compound 2; then compounds 3 and 1 (each within the scatter of the next).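

In this assay, hydrogen in place of ethyl on an oxygen next to a carbonyl group gives a 1.3-fold lower number from compound 1 to compound 3 (0.10 log units; within the scatter), the first single-place step available in this series. On this read-out, ethoxycarbonyl and carboxy therefore cannot be told apart on the core of compound 1, and losing the ethyl with its 2 heavy atoms does not separate the two compounds. Nothing at hand accounts for this result or says why the two compounds read alike.

Going by these compounds, it remains open whether any other group at this place would separate from these two, such as a longer chain on the same oxygen (a butyl ester), a primary carboxamide or a hydroxymethyl group in place of the ethoxycarbonyl. Also open, on these data alone, is what a methylpiperazine amide would do on its own on the core of compound 1, since compound 2 differs from compound 1 at several places and its number cannot be assigned to any one of them.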